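The source may hold more compounds than are shown below. What is called first, only, known or untested is meant among the compounds shown, and "the series" means these compounds.

Measured so far:
- compound 1 `COc1ccc(OC(C)C(=O)Nc2ccc3oc(-c4ccncc4)nc3c2)cc1`: > 5000 nM in an assay on isolated protein for inhibition of GMP reductase 2 (Homo sapiens), read by spectrophotometry (a lower number here means a stronger inhibitor, a higher number a weaker inhibitor), a limit of the assay rather than a number
- compound 2 `COc1ccc(-c2nc3cc(NC(=O)[C@H](C)Oc4ccccc4CN)ccc3o2)cc1`: > 5000 nM in this assay, a limit of the assay
- compound 3 `C[C@H](Oc1cccc(F)c1F)C(=O)Nc1ccc2oc(-c3ccc(F)cc3)nc2c1`: > 5000 nM in this assay, a limit of the assay

Among the measured compounds shown here, compound 2 stands at a limit only; no number separates it from the other two members, and no measured step can be drawn, since every value shown sits at the same limit (the limit of > 5000 nM in this assay, at which 3 of the 3 values shown sit).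

Compound 4 `COc1ccc(-c2nc3cc(NC(=O)[C@H](C)Oc4cccc(Cl)c4Cl)ccc3o2)cc1` is not yet measured. It differs from compound 2 in one place: 2,3-dichlorophenyl in place of 2-(aminomethyl)phenyl on an oxygen on a saturated carbon. Because all three values shown sit at the limit (the limit of > 5000 nM in this assay, at which 3 of the 3 values shown sit), there is no direction within the series to lean on, and the expected step that the limit leaves unreadable from compound 2 to compound 4 is none beyond the scatter. Compound 4 is therefore expected to read 8000 nM in this assay, most likely again as a limit, within 2000 nM to 40000 nM.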

Compound 4, inhibition constant: > 5000 nM
Compound 4: a limit, no number; the forecaster's own chance of this, stated with the estimate: 75%; the middle value does not contradict the limit.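

No step can be read between compound 2 and compound 4, since both stand at a limit: the limit of > 5000 nM in this assay, at which 4 of the 4 values shown sit.
The compounds shown leave open whether 2,3-dichlorophenyl and 2-(aminomethyl)phenyl differ at all in their effect, and which change, if any, would give this series a number rather than a limit.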